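Piperidine to methylpiperazine on the shared core

The source may hold more compounds than are shown below. What is called first, only, known or untested is meant among the compounds shown, and "the series" means these compounds.

Values in a functional assay on A-375 cells (Homo sapiens) for cytotoxicity, read by MTT assay, with a stated time of 72 h; a lower number here means a stronger inhibitor, a higher number a weaker inhibitor:
- compound 1 `O=C1c2c[n+]([O-])c3ccccc3c2C(=O)c2c1c1ccccc1n2CCCCN1CCNCC1`: 460 nM
- compound 2 `CCCCN1CCN(CCCCn2c3c(c4ccccc42)C(=O)c2c[n+]([O-])c4ccccc4c2C3=O)CC1`: 2150 nM
- compound 3 `O=C1c2c[n+]([O-])c3ccccc3c2C(=O)c2c1c1ccccc1n2CCCCN1CCCCC1`: 190 nM

Compound 3 has the lowest of these numbers, at 190 nM. Its nearest neighbour is compound 1, and compound 2 lies furthest away. Next in the series is compound 4 `CN1CCN(CCCn2c3c(c4ccccc42)C(=O)c2c[n+]([O-])c4ccccc4c2C3=O)CC1`. The change is 4-methylpiperazin-1-yl in place of (piperidin-1-yl)methyl on a saturated chain carbon, three bonds along the chain from an aromatic nitrogen. Read further out, 3-(4-methylpiperazin-1-yl)propyl takes the place of 4-(piperidin-1-yl)butyl.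

Within the data shown here, two measured steps bear on the ring part of this change. Piperidin-1-yl in place of piperazin-1-yl gave a 2.4-fold lower number from compound 1 to compound 3 (0.38 log units; beyond the scatter), a modest step, so a return to a piperazine points to a higher number. Piperidin-1-yl in place of 4-butylpiperazin-1-yl gave an 11-fold lower number from compound 2 to compound 3 (1.05 log units; beyond the scatter), a large step, and a 4.7-fold higher number from compound 1 to compound 2 (0.67 log units; beyond the scatter) shows that a substituent on the ring nitrogen can also raise the number. Among the measured compounds shown here, no measured pair isolates the shorter chain, which widens the range. In this assay a modest move to a higher number is expected, and the expected step is a 2.9-fold higher number from compound 3 to compound 4 (0.46 log units; beyond the scatter). For compound 4 the estimate is 550 nM, with an expected range of 200 nM to 1500 nM.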

Compound 4, half-maximal inhibitory concentration: 470 nM
Compound 4: the middle estimate sits 1.2-fold (0.07 log units) above what was measured, and the stated range covers the measured number.
By their numbers in this assay, from the lowest: compound 3; then compounds 1 and 4 (each within the scatter of the next); then compound 2.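

In this assay the step from piperidine to a methylated piperazine with a shorter chain, 4-(piperidin-1-yl)butyl to 3-(4-methylpiperazin-1-yl)propyl, gives a 2.5-fold higher number from compound 3 to compound 4 (0.39 log units; beyond the scatter), so compound 3 keeps the lowest number and this position accepts the new group at a modest cost. The step of a 4.6-fold lower number from compound 2 to compound 4 (0.66 log units; beyond the scatter) shows that a substituted piperazine at this place does not in itself bring the high number of compound 2, since the pair differs in both the substituent on the ring nitrogen and the chain. The step of a 1.0-fold higher number from compound 1 to compound 4 (0.01 log units; within the scatter) leaves these two compounds unseparated, although they too differ in both the methyl group and the chain, so the two changes may each be small or may offset each other.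

No pair shown isolates either change: a 4-(4-methylpiperazin-1-yl)butyl group would isolate the chain against compound 2 and compound 1, and a 3-(piperidin-1-yl)propyl group would do so against compound 3. Also open, as far as these compounds go, is how a ring oxygen, as in 4-(morpholin-4-yl)butyl, would read at this position.

No measurement at hand accounts for any of these steps.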